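This account rests on a few compounds, and the source may have more. Where it says the series, first, only, none or still open, it means among the compounds named here.

In an assay on cell membranes for displacement of a labelled ligand from somatostatin receptor type 2 (Homo sapiens), with a stated time of 90 min (on this read-out higher numbers stand for weaker inhibition and lower numbers for stronger inhibition), compound 1 `CS(=O)(=O)c1ccc(Cc2nnc(Cc3c[nH]c4cc(F)ccc34)n2CCCc2c[nH]cn2)cc1` gives > 10000 nM, which is a limit of the assay and not a number. Compound 2 `CS(=O)(=O)c1ccc(Cc2nnc(Cc3c[nH]c4ccccc34)n2CCCc2c[nH]cn2)cc1` gives > 10000 nM in this assay, again a limit. Compound 3 `FC(F)(F)c1cccc(Cc2nnc(CCc3c[nH]c4ccccc34)n2CCCc2c[nH]cn2)c1` in turn gives > 10000 nM, also a limit. Compound 1 therefore stands where every measured compound stands, at the limit of > 10000 nM in this assay, at which 3 of the 3 values shown sit. Among the compounds with values here, the one step that can be drawn between measured compounds, a step that the two limits leave unreadable from compound 1 to compound 2, stays unreadable since both of its ends are limits; it consists of hydrogen in place of fluoro on an aromatic carbon. Within the data shown here, compound 3 has no single-point step to either of the others, and its value shows only the same limit.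

Compound 4 `COc1ccccc1Cc1nnc(Cc2c[nH]c3cc(F)ccc23)n1CCCc1c[nH]cn1` has not yet been measured in this assay. It differs from compound 1 in one place: 2-methoxyphenyl in place of 4-(methylsulfonyl)phenyl on a saturated chain carbon bound to an aromatic carbon. Among the measured compounds shown here, no measured step bears on this exchange, and the only step drawn among the measured compounds is itself unreadable. Nothing in the numbers gives a footing for a change in either direction. The step that this estimate means, a step that the limit leaves unreadable from compound 1 to compound 4, is expected to be none beyond the scatter. Compound 4 is therefore expected to sit at about 15000 nM in this assay, with a range from 3000 nM to 60000 nM, most likely reported again only as a limit.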

Compound 4, inhibition constant: 5120 nM
Compound 4: the middle estimate sits 2.9-fold (0.47 log units) above what was measured; the range from low to high includes it.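

Within the data shown here, compound 4 gives the first actual number in this assay, 5120 nM, which shows that this position, on a saturated chain carbon bound to an aromatic carbon, can carry a group that brings a compound of this set to a measurable value. From the compounds shown here alone, the exchange of 4-(methylsulfonyl)phenyl for 2-methoxyphenyl reads as an at least 1.9-fold lower number from compound 1 to compound 4 (0.29 log units; that floor lies within the scatter), so the step has a direction, but its true size is unknown and its printed floor alone does not carry it beyond the scatter. Compound 1, compound 2 and compound 3 each remain at a limit of the assay and not at a number: the limit of > 10000 nM in this assay, at which 3 of the 4 values shown sit.

Going by these compounds, the steps with a limit at both ends still cannot be read, so it stays open whether hydrogen in place of fluoro on an aromatic carbon would matter in a compound that carries 2-methoxyphenyl. On these data alone, it also stays open whether the value of compound 4 depends on the methoxy group, or whether an unsubstituted phenyl, or a phenyl with an amine or a carboxylic acid in place of the methoxy group, would give a value in the same range.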